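Phenyl in Place of Pyridin-2-yl on the Aryl Amine

This account rests on a few compounds, and the source may have more. Where it says the series, first, only, none or still open, it means among the compounds named here.

Compound 1 `CCCc1ccc(Nc2cccc3c2C(=O)N(C2CCC(=O)NC2=O)C3=O)cc1`: 23%
Compound 2 `O=C1CCC(N2C(=O)c3ccc(Nc4ccccn4)cc3C2=O)C(=O)N1`: 9%
Compound 3 `Cc1ccccc1Nc1cccc2c1C(=O)N(C1CCC(=O)NC1=O)C2=O`: 7%

In an assay on FRT-Jurkat cells for inhibition of nuclear factor NF-kappa-B complex (Homo sapiens), read by flow cytometry, with a stated time of 24 h, tested at 10 uM (a higher number here means more inhibition at the concentration tested (going by the name of the read-out), a lower number less inhibition), compound 2 stands second highest of the three numbers; its value and that of compound 3 lie within the scatter, while compound 1 lies higher beyond it. Compound 4 `O=C1CCC(N2C(=O)c3ccc(Nc4ccccc4)cc3C2=O)C(=O)N1` differs from compound 2 by phenyl in place of pyridin-2-yl on a nitrogen on an aromatic ring. For the measured compounds named here, the single measured step, a number 16 percentage points lower from compound 1 to compound 3 (beyond the scatter), concerns 2-methylphenyl in place of 4-propylphenyl on a nitrogen on an aromatic ring and does not address exchanging pyridin-2-yl for phenyl. Without a step that bears on it, compound 4 is expected to stay near compound 2, with a number 3 percentage points higher from compound 2 to compound 4 (within the scatter) not beyond the scatter. The estimate for compound 4 is 12%, between 0% and 28%.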

Compound 4, a percentage reported as inhibition, at one concentration (the size of the read-out at that concentration, not a potency): 6%
Estimate against measurement, compound 4: 6 percentage points above; the range from low to high includes it.
By their numbers in this assay, from the lowest: compounds 4, 3 and 2 (each within the scatter of the next); then compound 1.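

In this assay, phenyl in place of pyridin-2-yl on a nitrogen on an aromatic ring gives a number 3 percentage points lower from compound 2 to compound 4 (within the scatter). Unlike the earlier step, this one concerns the ring nitrogen and its single hydrogen-bond acceptor, and at this position compound 2 and compound 4 cannot be told apart. Nothing on hand explains this result. Still open, from the compounds shown here alone, is whether an amine or a carboxylic acid on the phenyl of compound 4 would move the number beyond the scatter. Also open, going by these compounds, is how 4-propylphenyl would read on the core of compound 4.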